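Shortening the chain and swapping the amine on a flavone core

The source may hold more compounds than are shown below. What is called first, only, known or untested is meant among the compounds shown, and "the series" means these compounds.

Measured so far:
compound 1 `CN(C)CCCCCCCCCOc1ccc2oc(-c3ccccc3)cc(=O)c2c1` gives 334 nM
compound 2 `O=c1cc(-c2ccccc2)oc2ccc(OCCCN3CCC(O)CC3)cc12` gives 130 nM

Both were tested in an assay on isolated protein (Cavia porcellus) with Sigma non-opioid intracellular receptor 1 (Homo sapiens) as the target, read by radioligand binding; a higher number here means a weaker inhibitor, a lower number a stronger inhibitor. Going by the values given here, compound 2 holds the lowest of the two numbers, and the only step known so far, a 2.6-fold lower number from compound 1 to compound 2 (0.41 log units; beyond the scatter), is modest but beyond the scatter. Compound 3 `CCN(CC)CCCCCCOc1ccc2oc(-c3ccccc3)cc(=O)c2c1` has not yet been measured. It differs from compound 2 by 3-(diethylamino)propyl in place of 4-hydroxypiperidin-1-yl on a saturated chain carbon, three bonds along the chain from an oxygen on an aromatic ring. Among the compounds with values here, this partly reverses the only measured step: an open-chain tertiary amine returns, as in compound 1, though on a shorter chain than the one in compound 1. Within the data shown here, that single step, a 2.6-fold lower number from compound 1 to compound 2 (0.41 log units; beyond the scatter), is the only guide and points toward a somewhat higher number. A step in this assay of modest size upward, or none beyond the scatter, is therefore expected, namely a 1.5-fold higher number from compound 2 to compound 3 (0.19 log units; within the scatter). Compound 3 is estimated at 200 nM, with a range from 70 nM to 550 nM.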

Compound 3, half-maximal inhibitory concentration: 91 nM
The estimate for compound 3 lay 2.2-fold (0.34 log units) above the measured number, and the stated range covers the measured number.
By their numbers in this assay, from the lowest: compounds 3 and 2 (each within the scatter of the next); then compound 1.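

In this assay, 3-(diethylamino)propyl in place of 4-hydroxypiperidin-1-yl gives a 1.4-fold lower number from compound 2 to compound 3 (0.15 log units; within the scatter) and so cannot be told apart from the ring at this position, although the entering group has no ring and 0 hydrogen-bond donors. Among these compounds, then, neither the ring nor its hydroxyl is required for a number of this size. Diethylamino in place of 3-(dimethylamino)propyl gives a 3.7-fold lower number from compound 1 to compound 3 (0.56 log units; beyond the scatter), which shows that an open-chain amine can also reach this range, but no measured evidence explains these numbers.

The compounds shown cannot separate the ring from its hydroxyl, which a plain piperidine ring on the same chain could do. Nor can they separate the amine from the chain length in the step from compound 1, which a dimethylamino group on the chain of compound 3 could do.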